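The compounds below may be only part of what the source reports. "The series", "measured", "known", "first", "only" and "open" are said of these compounds alone.

Series notes on a functional assay on MIA PaCa-2 cells (Homo sapiens) for inhibition, read by MTT assay, with a stated time of 4 days; on this read-out higher numbers stand for weaker inhibition and lower numbers for stronger inhibition. Compound 1 `CCOC(=O)NC(c1ccccc1)c1ccc(Cl)cc1` gives 142000 nM. Compound 2 `O=C1NCCN1C(c1ccccc1)(c1ccccc1)c1ccccc1` gives 31000 nM. Compound 3 `COc1cc(NC(C)CCCNC(=O)NNC(=O)N(CCO)CCO)c2ncccc2c1` returns only a limit, > 250000 nM, so no number is in hand for it. Where compound 3 stands is thus fixed only by the limit of > 250000 nM in this assay, at which 1 of the 3 values shown sits, and no measured step connects it to compound 1 or compound 2. Compound 4 `COc1cc(NC(C)CCCNC(=O)Nc2ccc(Cl)c(C(F)(F)F)c2)c2ncccc2c1` differs from compound 3 by a single exchange, (4-chloro-3-(trifluoromethyl)phenyl in place of (bis(2-hydroxyethyl)carbamoyl)amino on an amide-type nitrogen). Among the compounds with values here, no measured step among the three compounds tells the size of such a change; the expectation is nonetheless for a step to stronger inhibition beyond the scatter, an at least 41-fold lower number from compound 3 to compound 4 (1.61 log units; beyond the scatter). Compound 4 is accordingly estimated at 6000 nM, with a likely range from 1000 nM to 40000 nM.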

Compound 4, half-maximal inhibitory concentration: 4000 nM
Estimate against measurement, compound 4: 1.5-fold (0.18 log units) above, within the range that was stated.
By their numbers in this assay, from the lowest: compound 4; then compound 2; then compound 1. At a limit, above all of these: compound 3.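

In this assay, the amide-type nitrogen whose other neighbour is the carbonyl carbon proves a place where a single exchange matters: 4-chloro-3-(trifluoromethyl)phenyl in place of (bis(2-hydroxyethyl)carbamoyl)amino gives an at least 62-fold lower number from compound 3 to compound 4 (1.79 log units; beyond the scatter). The size of this step is only a bound, because compound 3 has a limit and no number: the limit of > 250000 nM in this assay, at which 1 of the 4 values shown sits. Of the two compounds on this core, only compound 4 carries a number.

From the compounds shown here alone, it remains open whether the step depends on the aromatic ring or on its chloro and trifluoromethyl groups. A cyclohexyl group or an unsubstituted phenyl on the same nitrogen would separate these.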